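The source may hold more compounds than are shown below. What is called first, only, known or untested is meant among the compounds shown, and "the series" means these compounds.

Of the compounds shown here, three of the shared core have been measured in a functional assay on HT-29 cells (Homo sapiens) for cytotoxicity, read by MTT assay, with a stated time of 72 h; on this read-out higher numbers stand for weaker inhibition and lower numbers for stronger inhibition. Compound 1 `COc1cc2c(Oc3ccc(NC(=O)/C=C/S(=O)(=O)c4ccccc4OC)cc3F)ccnc2cc1OCCCN1CCN(C)CC1` gives 270 nM. Going by the values given here, compound 2 `COc1cc2c(Oc3ccc(NC(=O)/C=C/S(=O)(=O)c4ccccc4OC)cc3F)ccnc2cc1OCCCN1CCCCC1` gives 660 nM; the step of a 2.4-fold higher number from compound 1 to compound 2 (0.39 log units; beyond the scatter) is the only single-place step among the measured compounds. Compound 3 `COc1cc2c(Oc3ccc(NC(=O)/C=C/S(=O)(=O)c4ccccc4F)cc3F)ccnc2cc1OCCCN1CCC(C)CC1` gives 760 nM, the highest of the three numbers, within the scatter of compound 2 and beyond it against compound 1. Compound 4 `COc1cc2c(Oc3ccc(NC(=O)/C=C/S(=O)(=O)c4ccccc4OC)cc3F)ccnc2cc1OCCCN1CCC(C)CC1` carries methoxy in place of fluoro on an aromatic carbon. Among the compounds with values here, no measured pair isolates this change; compound 2 and compound 3 differ in more than one place, and their numbers lie within the scatter of each other. The step of a 1.2-fold lower number from compound 3 to compound 4 (0.07 log units; within the scatter) is therefore expected to stay within the scatter. Compound 4 is estimated at 650 nM, range 300 nM to 1500 nM.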

Compound 4, half-maximal inhibitory concentration: 1960 nM
Estimate against measurement, compound 4: 3.0-fold (0.48 log units) below; the measured number lies above the stated range.
By their numbers in this assay, from the lowest: compound 1; then compounds 2 and 3 (each within the scatter of the next); then compound 4.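

In this assay, going by these compounds alone, (2-methoxyphenyl)sulfonyl in place of (2-fluorophenyl)sulfonyl gives a 2.6-fold higher number from compound 3 to compound 4 (0.41 log units; beyond the scatter) and is the first isolated reading of this change, ortho to a large group. With methoxy held, the chain end also matters: methyl in place of hydrogen on a saturated ring carbon gives a 3.0-fold higher number from compound 2 to compound 4 (0.47 log units; beyond the scatter), and 4-methylpiperidin-1-yl in place of 4-methylpiperazin-1-yl gives a 7.3-fold higher number from compound 1 to compound 4 (0.86 log units; beyond the scatter) for the series' widest step. Nothing available bears on the cause of these steps.

Going by these compounds, whether the methoxy step holds with piperidin-1-yl or 4-methylpiperazin-1-yl at the chain end stays open, as does the reading of chloro, ethoxy or hydroxy at this aromatic carbon.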